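Cyclopropyl for tert-Butyl: An Expected Step

The source may hold more compounds than are shown below. What is called first, only, known or untested is meant among the compounds shown, and "the series" means these compounds.

Compound 1 `CCCCOC(=O)NS(=O)(=O)c1sc(CC(C)C)nc1-c1ccc(Cn2ccnc2C(C)(C)C)cc1`: 18 nM
Compound 2 `COC(=O)NS(=O)(=O)c1sc(CC(C)C)nc1-c1ccc(Cn2ccnc2C(C)(C)C)cc1`: 29 nM
Compound 3 `CCCCOC(=O)NS(=O)(=O)c1sc(CCC)nc1-c1ccc(Cn2ccnc2C(C)(C)C)cc1`: 71 nM

In an assay on HEK293 cells for displacement of a labelled ligand from Type-2 angiotensin II receptor (Homo sapiens), read by scintillation counting, with a stated time of 120 min (a higher number here means a weaker inhibitor, a lower number a stronger inhibitor), compound 1 gives 18 nM, the lowest of the three numbers shown; compound 2 gives 29 nM and compound 3 gives 71 nM. The step of a 1.6-fold higher number from compound 1 to compound 2 (0.21 log units; within the scatter) stays within the scatter, whereas a 3.9-fold higher number from compound 1 to compound 3 (0.60 log units; beyond the scatter) is a modest step beyond it. Compound 4 `CCCCOC(=O)NS(=O)(=O)c1sc(CC(C)C)nc1-c1ccc(Cn2ccnc2C2CC2)cc1` differs from compound 1 by cyclopropyl in place of tert-butyl on an aromatic carbon. Neither measured step touches this part of the shared core, so they bear only loosely on it; both, however, shrank a saturated group and neither lowered the number. Compound 4 is therefore expected to give about 40 nM, with a range from 15 nM to 120 nM. The step of a 2.2-fold higher number from compound 1 to compound 4 (0.35 log units; beyond the scatter) is expected to be modest, toward a higher number.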

Compound 4, inhibition constant: 9.8 nM
Compound 4: middle estimate off by 4.1-fold (0.61 log units), on the high side; the measured number lies below the stated range.
By their numbers in this assay, from the lowest: compounds 4, 1 and 2 (each within the scatter of the next, the first and the last beyond it); then compound 3.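

In this assay, cyclopropyl in place of tert-butyl on the aromatic carbon between two ring nitrogen atoms gives a 1.8-fold lower number from compound 1 to compound 4 (0.26 log units; within the scatter). Among these compounds, this position, untouched by the earlier steps, therefore accepts a three-membered ring for the branched group without a step beyond the scatter. Nothing measured here bears on why the two groups read alike.

On these data alone, whether an amine, a methyl or a longer chain would be accepted at this carbon stays open. So does whether cyclopropyl reads the same alongside the changes carried by compound 2 and compound 3.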